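The source may report more compounds than this note shows. Statements on the series, on what has been measured and on what is new or still open speak of the compounds shown alone.

Measured so far:
- compound 1, `COc1ccc(NC(=O)COc2cc(C)nc3ccc(OC)cc23)cc1`, 4.22
- compound 2, `COc1ccc2nc(C)cc(OCC(=O)Nc3cc(F)cc(F)c3)c2c1`, 5.13
- compound 3, `COc1ccc2nc(C)cc(OCC(=O)Nc3ccccn3)c2c1`, 3.49

In a physicochemical assay for lipophilicity, read by HPLC, in phosphate buffer, measured as chromatographic lipophilicity, at pH 7.4 (a lower number here means a more polar compound, a higher number a more lipophilic compound), compound 3 stands lowest of the three, with compound 1 nearest and compound 2 furthest. Both steps that reach compound 3 brought the number down: a number 0.73 log units lower from compound 1 to compound 3 (beyond the scatter) and a number 1.64 log units lower from compound 2 to compound 3 (beyond the scatter). Each of them swapped a substituted phenyl for pyridin-2-yl on the amide-type nitrogen.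

Compound 4, `COc1ccc2nc(C)cc(OCC(=O)Nc3cccnc3)c2c1`, keeps the same atoms as compound 3 but joins them differently: pyridin-3-yl in place of pyridin-2-yl on an amide-type nitrogen. For the measured compounds named here, no measured step moves a ring nitrogen within an otherwise unchanged ring, so the two steps into compound 3 bear only loosely on this change; they show that a pyridyl ring here sits well below the phenyl analogues, and that remains true for compound 4. The step from compound 3 to compound 4 is expected to be small, a number 0.34 log units lower from compound 3 to compound 4 (beyond the scatter), tending slightly downward. For compound 4 the estimate in this assay is 3.15, within 2.6 to 3.7.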

Compound 4, distribution coefficient: 2.46
Estimate against measurement, compound 4: 0.69 log units above; measured number outside the range, below it.
By their numbers in this assay, from the lowest: compound 4; then compound 3; then compound 1; then compound 2.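

In this assay, swapping pyridin-2-yl for pyridin-3-yl on the amide-type nitrogen leaves the atoms unchanged and only joins them differently, yet it produces a large step (a number 1.03 log units lower from compound 3 to compound 4 (beyond the scatter)). The two pyridyl groups therefore cannot be treated as interchangeable at this position, and the way the ring is joined matters in its own right. Compound 4 also sits far under both phenyl analogues (a number 1.76 log units lower from compound 1 to compound 4 (beyond the scatter); a number 2.67 log units lower from compound 2 to compound 4 (beyond the scatter)), and the second of these is the widest gap among the four compounds. Nothing available here accounts for the difference between the two pyridyl groups.

The compounds shown leave open where pyridin-4-yl on the same nitrogen would fall. They also leave open whether a methoxy group or a fluorine on the pyridine ring would keep the two pyridyl groups this far apart.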